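Chloropurine benzyl series: removing the amino group

This account rests on a few compounds, and the source may have more. Where it says the series, first, only, none or still open, it means among the compounds named here.

As far as these compounds go, compound 2 `Nc1nc(Cl)c2ncn(Cc3ccccc3CCl)c2n1` gives "not determined" (no result reported) in a functional assay on RXF 393 cells (Homo sapiens) for cytotoxicity, read by sulforhodamine B assay, with a stated time of 48 h (a lower number here means a stronger inhibitor of growth, a higher number a weaker inhibitor of growth), so its standing on the numbers is unknown. The measured anchors are compound 1 `ClCc1ccc(Cn2cnc3c(Cl)ncnc32)cc1`, which gives 2300 nM in this assay, and compound 3 `ClCc1ccccc1Cn1cnc2nc(Cl)nc(Cl)c21`, which gives 1 nM in this assay; these two differ from each other in more than one place, so their gap cannot be assigned to a single change. Compound 4 `ClCc1ccccc1Cn1cnc2c(Cl)ncnc21` arises from compound 2 by hydrogen in place of amino on an aromatic carbon. For the measured compounds named here, no step between measured compounds shows the effect of this change, so its size and direction in this assay cannot be read from the data. Compound 4 is estimated at 150 nM, within a wide range from 5 nM to 3000 nM, resting only on the spread shown by compound 1 and compound 3.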

Compound 4, concentration for 50% growth inhibition: 440 nM
The estimate for compound 4 lay 2.9-fold (0.47 log units) below the measured number, and the stated range covers the measured number.
By their numbers in this assay, from the lowest: compound 3; then compound 4; then compound 1.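

No new step can be read from compound 4, compound 1 or compound 3, as compound 2 has no number. As far as these compounds go, the effect of removing the amino group in this assay stays open, and no measured property bears on this result.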